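The source may hold more compounds than are shown below. What is called first, only, known or untested is meant among the compounds shown, and "the series" means these compounds.

Measured compounds:
Compound 1, `Cc1ccc2[nH]c(=O)c(/C=N/c3ccc(O)cc3)cc2c1`, gives 235000 nM in a functional assay, read by spectrophotometry, with a stated time of 5 min; on this read-out higher numbers stand for weaker inhibition and lower numbers for stronger inhibition.
Compound 2, `CCCC/N=C/c1cc2cc(C)ccc2[nH]c1=O`, gives 379000 nM in this assay.

Compound 1 holds the lower of the two numbers, but the gap to compound 2, a 1.6-fold higher number from compound 1 to compound 2 (0.21 log units; within the scatter), is within the scatter, so no order between the two can be read.

Compound 3, `O=c1[nH]c2ccccc2cc1/C=N/c1ccc(O)cc1`, has not yet been measured. It differs from compound 1 by hydrogen in place of methyl on an aromatic carbon. Within the data shown here, no measured step bears on this change: the only one available, a 1.6-fold higher number from compound 1 to compound 2 (0.21 log units; within the scatter), concerns the group on the double-bonded nitrogen, and the aromatic methyl is kept in both compound 1 and compound 2. With nothing of this kind at hand, the expected step in this assay from compound 1 to compound 3 is none beyond the scatter. Compound 3 is therefore estimated at 235000 nM, range 110000 nM to 500000 nM, an expected step of no change at the digits printed from compound 1 to compound 3 (within the scatter).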

Compound 3, half-maximal inhibitory concentration: 306000 nM
Compound 3: middle estimate off by 1.3-fold (0.11 log units), on the low side, and the stated range covers the measured number.
By their numbers in this assay, from the lowest: compounds 1, 3 and 2 (each within the scatter of the next).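

In this assay, hydrogen in place of methyl on this aromatic carbon gives a 1.3-fold higher number from compound 1 to compound 3 (0.11 log units; within the scatter), so the two compounds cannot be told apart. Among these compounds, this is the first look at the fused ring system rather than the group on the double-bonded nitrogen, and at this position the methyl can be lost with no step beyond the scatter when 4-hydroxyphenyl is kept on that nitrogen. Nothing available explains this result.

As far as these compounds go, whether a larger or different group at this carbon, such as chlorine, methoxy or a carboxylic acid, would move the number beyond the scatter remains open. Also open, from the compounds shown here alone, is whether the same exchange of methyl for hydrogen would read the same with butyl on the double-bonded nitrogen, as in compound 2.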